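The compounds below may be only part of what the source reports. "The series", "measured", "known", "first", "only" and "open" are said of these compounds alone.

The three measured compounds, all in a functional assay on SK-OV-3 cells (Homo sapiens) for antiproliferative activity, read by MTT assay, with a stated time of 72 h (a higher number here means a weaker inhibitor, a lower number a stronger inhibitor), are:

Compound 1 `O=C(CCc1cccc2c1B(O)OC2)Nc1ccc(F)cc1` gives 720 nM.
Compound 2 `O=C(CCc1cccc2c1B(O)OC2)Nc1ccc(Cl)cc1` gives 5000 nM.
Compound 3 `O=C(CCc1cccc2c1B(O)OC2)Nc1ccc(I)cc1` gives 51000 nM.

Compound 1 has the lowest number of the three, and its gaps to compound 2 and compound 3 are both beyond the scatter, so it is the strongest inhibitor of this small set. Compound 4 `O=C(CCc1cccc2c1B(O)OC2)Nc1ccc([N+](=O)[O-])cc1` has not yet been measured. It differs from compound 1 in one place: nitro in place of fluoro on an aromatic carbon.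

The measured steps all concern the same position, where one halogen replaces another: a 6.9-fold higher number from compound 1 to compound 2 (0.84 log units; beyond the scatter), a 71-fold higher number from compound 1 to compound 3 (1.85 log units; beyond the scatter) and a 10-fold higher number from compound 2 to compound 3 (1.01 log units; beyond the scatter). Each move away from fluoro at this carbon gave a higher number, and the larger the replacement, the larger the rise. Nitro is not a halogen, so these steps bear on compound 4 only indirectly; still, they give no sign that any change at this position is tolerated, and nitro enters with more heavy atoms than the fluoro it replaces. A weakening step is therefore expected, of a size between the chloro and iodo steps: a 5.6-fold higher number from compound 1 to compound 4 (0.74 log units; beyond the scatter). For compound 4 the estimate in this assay is 4000 nM, with a range from 800 nM to 25000 nM.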

Compound 4, half-maximal inhibitory concentration: 83000 nM
Beside the measured number, compound 4's estimate is 21-fold (1.32 log units) below it; measured number outside the range, above it.
By their numbers in this assay, from the lowest: compound 1; then compound 2; then compounds 3 and 4 (each within the scatter of the next).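

At this carbon, nitro is a costly change in this assay: it gives a 120-fold higher number from compound 1 to compound 4 (2.06 log units; beyond the scatter) and also a 17-fold higher number from compound 2 to compound 4 (1.22 log units; beyond the scatter), so the loss is not confined to replacing one halogen with another. The comparison with iodo gives a 1.6-fold higher number from compound 3 to compound 4 (0.21 log units; within the scatter), which is within the scatter, so nitro and iodo cannot be told apart here even though one is a halogen and the other is not, while compound 1 with its fluoro remains the strongest inhibitor of the four. No measurement is available that explains why fluoro gives the lowest number or why nitro and iodo end up level, so the reason for these results remains unknown.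

The four compounds do not show whether fluoro is unusual at this carbon or whether other groups can match it, and a methyl, a hydroxyl or an amine there would test this. A bromo would fill the gap in the halogen series, and a carboxylic acid would show whether a second group that is not a halogen also gives a high number.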